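A few compounds are considered here, and "the series" means these few. Any claim that something is new, unique, unknown or untested is made for them only; others in the source may bear on it.

Compound 1 (`O=C(O)CCCCCn1nc(-c2ccccc2)c(-c2ccccc2)c1-c1ccccc1`) was tested in a functional assay for inhibition, with Homo sapiens as the target (a higher number here means a weaker inhibitor, a lower number a stronger inhibitor), where the read-out is a half-maximal inhibitory concentration. Compound 1 gives > 78000 nM, which is a limit of the assay and not a number. Compound 2 (`O=C(O)CCCCCCCCCn1cc(-c2ccccc2)c(-c2ccccc2)n1`) gives > 81000 nM, and this too is a limit. Compound 1 therefore has no measured potency, and the two results cannot be ranked against each other.

Compound 3 (`CC(C)(C)OC(=O)COCCCCCCn1nc(-c2ccccc2)c(-c2ccccc2)c1-c1ccccc1`) keeps the core of compound 1 but alters its chain: ((tert-butoxycarbonyl)methoxy)methyl in place of carboxy on a saturated chain carbon, five bonds along the chain from an aromatic nitrogen. Here ((tert-butoxycarbonyl)methoxy)methyl takes the place of carboxy on a saturated chain carbon, five bonds along the chain from an aromatic nitrogen. Going by the values given here, no measured pair of compounds shows what this kind of change does in this assay, so the only starting point is the limit of compound 1. The expected change is none beyond the scatter, with no direction favoured, and the estimated step is a step that the limit leaves unreadable from compound 1 to compound 3. The assay may well report only a limit again. For compound 3 the expected value is 80000 nM, within an estimated range of 15000 nM to 200000 nM.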

Compound 3, half-maximal inhibitory concentration: > 62000 nM
Compound 3: a limit, no number; the forecaster's own chance of this, stated with the estimate: 75%; the middle value is on the limit's open side.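

In this assay compound 3 gives only a limit of the assay, as compound 1 does, and the step between compound 1 and compound 3 cannot be read. The compounds shown leave open how strongly any of them inhibits, and whether ((tert-butoxycarbonyl)methoxy)methyl in place of carboxy changes that at all.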